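Aryl exchange on the saturated ring carbon of compound 2

The source may hold more compounds than are shown below. What is called first, only, known or untested is meant among the compounds shown, and "the series" means these compounds.

Measured so far in a functional assay on PC-3 cells (Homo sapiens) for antiproliferative activity, read by MTT assay, tested at 1 uM; a higher number here means a stronger effect of the compound at the concentration tested, a lower number a weaker effect:
compound 1 `COc1ccc(/C=N/NC(=O)c2cc(OC)c(OC)c(OC)c2)c(OC)c1` gives 10%
compound 2 `COc1cc(C2=NN(C(C)=O)C(c3cccc(OC)c3OC)O2)cc(OC)c1OC` gives 35%
compound 3 `COc1cc(C(=O)N/N=C/c2cccc(C(F)(F)F)c2)cc(OC)c1OC` gives 51%

Compound 2 stands second of the three numbers in this assay. Its nearest neighbour is compound 3, whose value lies higher by a margin beyond the scatter; compound 1 sits further away, lower by a margin that is also beyond the scatter. No pair of these compounds differs in only one place, so no single step can be read from them.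

Compound 4 `COc1cc(C2=NN(C(C)=O)C(c3ccc(F)cc3)O2)cc(OC)c1OC` is not yet measured. It differs from compound 2 as follows: 4-fluorophenyl in place of 2,3-dimethoxyphenyl on a saturated ring carbon. The acetyl group on the ring nitrogen and the trimethoxyphenyl on the other side of the core are kept.

Among the compounds with values here, no measured step speaks directly to this exchange. The values of compound 1 and compound 3 show that a methoxy-rich aryl gave the lowest number and a fluorinated aryl the highest, but those two sit on a different core, so the hint is weak. A small upward step is expected in this assay, possibly within the scatter. Compound 4 is estimated at 42%, with a range from 22% to 62%, which means an expected step of a number 7 percentage points higher from compound 2 to compound 4 (within the scatter).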

Compound 4, a percentage reported as inhibition, at one concentration (the size of the read-out at that concentration, not a potency): 0%
Compound 4: the middle estimate sits 42 percentage points above what was measured; measured number below the stated range.
By their numbers in this assay, from the lowest: compounds 4 and 1 (each within the scatter of the next); then compound 2; then compound 3.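

In this assay the saturated ring carbon next to the ring oxygen proves sensitive to the aryl it carries. Within the data shown here, with the acetyl group and the trimethoxyphenyl kept, 4-fluorophenyl in place of 2,3-dimethoxyphenyl is a large loss (a number 35 percentage points lower from compound 2 to compound 4 (beyond the scatter)), and this is the first single-place step. On this core, the 2,3-dimethoxyphenyl is therefore the better of the two aryls compared, and this position clearly influences the read-out. No available data explain this step.

The step changes both the methoxy groups and the fluorine at once, so it cannot show whether losing the former or gaining the latter matters more. The compounds shown also leave open how plain phenyl, or an aryl bearing a dimethylamino group or a carboxylic acid, would behave at this position.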